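Replacing the methylsulfanyl side chain: compound 3 to compound 4

The compounds below may be only part of what the source reports. "The series", "measured", "known", "first", "only" and "open" are said of these compounds alone.

Measured so far:
compound 1 `C[C@@H](O)[C@H](NC(=O)CN(c1nc(Cl)nc2[nH]cnc12)C1CC1)C(=O)O` — 37.6%
compound 2 `CC(C)[C@H](NC(=O)CN(c1nc(Cl)nc2[nH]cnc12)C1CC1)C(=O)OCc1ccccc1` — 27.3%
compound 3 `CSCC[C@H](NC(=O)CN(c1nc(Cl)nc2[nH]cnc12)C1CC1)C(=O)O` — 5.67%

In a functional assay on the whole organism (Tail, strain ICR) with Mus musculus as the target, in the tail flick test, with a stated time of 120 min, at a dose of 25 umol/kg by the oral route (on this read-out higher numbers stand for a stronger effect at the one dose given and lower numbers for a weaker effect), compound 3 gives the lowest of the three numbers; compound 2 lies closest, compound 1 furthest, both higher than compound 3 beyond the scatter. Compound 4 `CC(C)[C@H](NC(=O)CN(c1nc(Cl)nc2[nH]cnc12)C1CC1)C(=O)O` differs from compound 3 in one place: isopropyl in place of 2-(methylsulfanyl)ethyl on a saturated chain carbon bound to an amide-type nitrogen and a carbonyl carbon. Going by the values given here, one measured step bears on this place: a number 31.9 percentage points lower from compound 1 to compound 3 (beyond the scatter), so exchanging the group there has already moved this read-out strongly. Compound 2 also carries isopropyl in that place and gives 27.3%, though it differs from compound 4 elsewhere. A rise beyond the scatter is therefore expected, a number 24.3 percentage points higher from compound 3 to compound 4 (beyond the scatter). Compound 4 is estimated at 30%, expected between 12% and 50%.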

Compound 4, a percentage reported as activity, at one dose (the size of the read-out at that dose, not a potency): 17.1%
Compound 4: the middle estimate sits 12.9 percentage points above what was measured, within the range that was stated.
By their numbers in this assay, from the lowest: compound 3; then compound 4; then compound 2; then compound 1.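

At the saturated chain carbon bound to an amide-type nitrogen and a carbonyl carbon, this assay now separates all three groups among the free acids: isopropyl in place of 2-(methylsulfanyl)ethyl gives a number 11.4 percentage points higher from compound 3 to compound 4 (beyond the scatter), while isopropyl in place of 1-hydroxyethyl gives a number 20.5 percentage points lower from compound 1 to compound 4 (beyond the scatter). A second place also comes into view, as hydrogen in place of benzyl on an oxygen next to a carbonyl group gives a number 10.2 percentage points lower from compound 2 to compound 4 (beyond the scatter). Nothing available explains these steps.

Open, going by these compounds, is how an amine or a longer chain would read at the saturated chain carbon, and how methyl or ethyl would compare with benzyl on that oxygen.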